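The compounds below may be only part of what the source reports. "The series", "measured", "known", "first", "only" and "open" are said of these compounds alone.

Compound 1 `COc1cc2c(Oc3ccc(NC(=O)NN4C(=O)CSC4c4c(F)cccc4F)cc3Cl)ccnc2cc1OCCCN1CCCC1` and compound 2 `COc1cc2c(Oc3c(F)cc(NC(=O)NN4C(=O)C(C)(C)SC4c4c(F)cccc4F)cc3F)ccnc2cc1OCCCN1CCCC1` were measured in a functional assay on A549 cells (Homo sapiens) for antiproliferative activity, read by MTT assay, with a stated time of 72 h (on this read-out lower numbers stand for stronger inhibition and higher numbers for weaker inhibition), where compound 1 gives 880 nM and compound 2 gives 1450 nM. Compound 3 `COc1cc2c(Oc3c(F)cc(NC(=O)NN4C(=O)CSC4c4c(F)cccc4F)cc3F)ccnc2cc1OCCCN1CCc2sccc2C1` shares the core of these two but carries a different group at the end of the chain. In this assay compound 3 reaches only the limit of the measurement and gives no number, > 20000 nM. This is the point noted as the limit of > 20000 nM in this assay, at which 1 of the 3 values shown sits, so compound 3 stands at the weak end of everything seen so far, with no number to place it against compound 1 or compound 2.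

Compound 4 `COc1cc2c(Oc3c(F)cc(NC(=O)NN4C(=O)CSC4c4c(F)cccc4F)cc3F)ccnc2cc1OCCCN1C[C@H]2CCCC[C@H]2C1` differs from compound 3 in one place: a group of 9 heavy atoms (8 carbon, 1 nitrogen; one five-membered non-aromatic ring with 1 hetero atom, one six-membered non-aromatic ring of carbon only) in place of a group of 9 heavy atoms (7 carbon, 1 nitrogen, 1 sulfur; one five-membered aromatic ring with 1 hetero atom, one six-membered non-aromatic ring with 1 hetero atom), on a saturated chain carbon, three bonds along the chain from an oxygen on an aromatic ring. Among the measured compounds shown here, no measured pair shows this exact exchange, so the size of the step from compound 3 to compound 4 is not known from the data. The two compounds with a smaller group at that position, compound 1 and compound 2, sit far from the limit, while compound 3, with a larger group, sits at it; compound 4 keeps a large group there. The step of an at least 1.3-fold lower number from compound 3 to compound 4 (0.12 log units; that floor lies within the scatter) is therefore expected to be small or none beyond the scatter, and compound 4 is estimated at 15000 nM, between 4000 nM and 40000 nM.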

Compound 4, half-maximal inhibitory concentration: 1930 nM
Beside the measured number, compound 4's estimate is 7.8-fold (0.89 log units) above it; the measured number lies below the stated range.
By their numbers in this assay, from the lowest: compounds 1, 2 and 4 (each within the scatter of the next, the first and the last beyond it). At a limit, above all of these: compound 3.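

In this assay, the exchange on the saturated chain carbon, three bonds along the chain from an oxygen on an aromatic ring, gives an at least 10-fold lower number from compound 3 to compound 4 (1.01 log units; beyond the scatter). Both the group that leaves and the group that enters hold 9 heavy atoms, so the count of heavy atoms alone does not set the result at this position, and what differs is the make-up of the rings: a five-membered aromatic ring with 1 hetero atom, here sulfur, gives way to a six-membered non-aromatic ring of carbon only, while the nitrogen-bearing ring goes from six-membered to five-membered. The value of compound 3 is a limit of the assay and not a number, so the step gives only a floor for the size of the change: the limit of > 20000 nM in this assay, at which 1 of the 4 values shown sits.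

The compounds shown do not separate the loss of the sulfur-bearing aromatic ring from the change in the nitrogen-bearing ring, and they leave open what the 2 defined stereocentres of the entering group contribute. As far as these compounds go, how a piperidine, a morpholine or a dimethylamino group would read at this place also remains open.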